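Swapping the Ester Arm for an Ethoxymethyl Chain

The source may report more compounds than this note shows. Statements on the series, on what has been measured and on what is new or still open speak of the compounds shown alone.

Compound 1 `COC(=O)/C=C/c1cccc(N(Cc2ccc(/C=C/c3cccc(F)c3)cc2)C(=O)C2CCCCC2)c1` in an assay on isolated protein with Bile acid receptor (Homo sapiens) as the target (on this read-out lower numbers stand for an effect already at smaller amounts and higher numbers for an effect only at larger amounts of compound), gives 86 nM.
Compound 2 `COC(=O)/C=C/c1cccc(N(Cc2ccc(-c3c(OC)cccc3OC)cc2)C(=O)C2CCCCC2)c1` gives 77 nM.
Compound 3 `COC(=O)/C=C/c1cccc(N(Cc2ccc(/C=C/C(=O)OCc3ccccc3)cc2)C(=O)C2CCCCC2)c1` gives > 1000 nM, which is a limit of the assay.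

Compound 3 therefore has no number of its own, only (the limit of > 1000 nM in this assay, at which 1 of the 3 values shown sits). Compound 4 `CCOC/C=C/c1ccc(CN(C(=O)C2CCCCC2)c2cccc(/C=C/C(=O)OC)c2)cc1` differs from it by ethoxymethyl in place of benzyloxycarbonyl on a double-bonded chain carbon bound to a double-bonded chain carbon. Going by the values given here, two measured steps bear on this change: an at least 11-fold higher number from compound 1 to compound 3 (1.06 log units; beyond the scatter) and an at least 12-fold higher number from compound 2 to compound 3 (1.11 log units; beyond the scatter), both large, both arising when the benzyloxycarbonyl group was introduced. Taking that group out again is expected to bring the number back down, though ethoxymethyl resembles neither earlier group, so the size is uncertain. The expected step is an at least 2.5-fold lower number from compound 3 to compound 4 (0.39 log units; beyond the scatter). Compound 4 is estimated at 400 nM, within 100 nM to 2000 nM.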

Compound 4, half-maximal effective concentration: 198000 nM
Estimate against measurement, compound 4: 500-fold (2.69 log units) below; measured number above the stated range.
By their numbers in this assay, from the lowest: compounds 2 and 1 (each within the scatter of the next); then compound 4.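

Taking out benzyloxycarbonyl does not by itself bring the number back down: ethoxymethyl on this chain carbon gives a 2300-fold higher number from compound 1 to compound 4 (3.36 log units; beyond the scatter), and the same change counted from the aromatic carbon gives a 2600-fold higher number from compound 2 to compound 4 (3.41 log units; beyond the scatter). So the position holds 3-fluorophenyl and 2,6-dimethoxyphenyl well, but the ring-free ethoxymethyl chain very poorly. The step from compound 3 to compound 4 cannot be read, because compound 3 carries only a limit: the limit of > 1000 nM in this assay, at which 1 of the 4 values shown sits.

Open, going by these compounds, is whether a plain phenyl ring, an amine or a longer carbon chain on this chain carbon would bring the number back down.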